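Aryl swap on the sulfonamide nitrogen of compound 3

The source may report more compounds than this note shows. Statements on the series, on what has been measured and on what is new or still open speak of the compounds shown alone.

- compound 1 `O=C(/C=C/c1cccnc1)NCCCc1ccc(S(=O)(=O)Nc2ccccc2)cc1` gives 4900 nM
- compound 2 `O=C(/C=C/c1cccnc1)NCCCCCCCc1cccc(S(=O)(=O)Nc2ccccc2)c1` gives 61.1 nM
- compound 3 `Cc1ccc(C)c(NS(=O)(=O)c2cccc(CCCCCCNC(=O)/C=C/c3cccnc3)c2)c1` gives 0.84 nM

All three values come from a functional assay on K562 cells (Homo sapiens) for inhibition, read by CCK-8 assay, with a stated time of 72 h; a higher number here means a weaker inhibitor, a lower number a stronger inhibitor. Compound 3 (0.84 nM) has the lowest number of the three, beyond the scatter against both compound 2 and compound 1. The next compound to be read is compound 4 `O=C(/C=C/c1cccnc1)NCCCCCCc1cccc(S(=O)(=O)Nc2ccc(C(F)(F)F)cc2)c1`, which carries 4-(trifluoromethyl)phenyl in place of 2,5-dimethylphenyl on a sulfonamide nitrogen and is otherwise the same as compound 3.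

For the measured compounds named here, no two measured compounds differ in one place only, so the size of this change in this assay cannot be read directly. Compound 2 at 61.1 nM differs from compound 3 in more than one place and guides the expectation only loosely. An upward step is expected, estimated at a 6.0-fold higher number from compound 3 to compound 4 (0.77 log units; beyond the scatter) and beyond the scatter. For compound 4 the estimate is 5 nM (expected range 0.8 nM to 35 nM).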

Compound 4, half-maximal inhibitory concentration: 44.9 nM
Estimate against measurement, compound 4: 9.0-fold (0.95 log units) below; the measured number lies above the stated range.
By their numbers in this assay, from the lowest: compound 3; then compounds 4 and 2 (each within the scatter of the next); then compound 1.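

In this assay, for the compounds shown here, the pair of compound 3 and compound 4 gives the first comparison that differs in one place only, and it shows a 53-fold higher number from compound 3 to compound 4 (1.73 log units; beyond the scatter) when 4-(trifluoromethyl)phenyl replaces 2,5-dimethylphenyl on the sulfonamide nitrogen. The result therefore ties the number directly to the aryl group at this position, with compound 3 the stronger inhibitor of the pair. No measurement here explains the step, and it cannot be divided between the departing methyl groups and the entering trifluoromethyl group.

Still open, on these data alone, is how plain phenyl, a phenyl carrying a single methyl group, or a phenyl carrying methoxy would read at this position with the rest of compound 3 unchanged. Also open, as far as these compounds go, is whether a pyridyl group or an aminophenyl group would be accepted there.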